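Cyclohexenyl in place of nitrophenyl: expected effect on binding

The source may report more compounds than this note shows. Statements on the series, on what has been measured and on what is new or still open speak of the compounds shown alone.

Three analogues sharing one core have been run in an assay on HEK293 cells for displacement of a labelled ligand from metabotropic glutamate receptor 5 (Rattus norvegicus); on this read-out lower numbers stand for stronger inhibition and higher numbers for weaker inhibition. Compound 1 `O=C(Nc1cc(-c2ccccc2)nn1-c1ccccc1)c1ccc(OC(F)(F)F)cc1` gives 265 nM. Compound 2 `O=C(Nc1cc(-c2ccccc2)nn1-c1ccccc1)c1ccc([N+](=O)[O-])cc1` gives 250 nM and stands second highest of the three numbers; the nearest number lies a 1.1-fold lower number from compound 1 to compound 2 (0.03 log units; within the scatter) and the furthest lies a 2.1-fold lower number from compound 2 to compound 3 (0.32 log units; beyond the scatter). Compound 3 `O=C(Nc1cc(-c2ccccc2)nn1-c1ccccc1Br)c1ccc([N+](=O)[O-])cc1` gives 120 nM.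

Compound 4 `O=C(Nc1cc(-c2ccccc2)nn1-c1ccccc1)C1=CCCCC1` has not been measured. It differs from compound 2 in one place: cyclohex-1-en-1-yl in place of 4-nitrophenyl on a carbonyl carbon. Neither measured step bears directly on this change: the step from compound 1 to compound 2 exchanged trifluoromethoxy for nitro on an aromatic carbon of the group that now leaves and stayed within the scatter, and the step from compound 2 to compound 3 altered the other aryl group. Among the compounds with values here, no step removes the aromatic ring from the carbonyl carbon, so the present data give no measured guide. A shift to a higher number beyond the scatter is expected, with wide uncertainty. The expected step is a 3.6-fold higher number from compound 2 to compound 4 (0.56 log units; beyond the scatter). For compound 4 the estimate in this assay is 900 nM, within 200 nM to 4000 nM.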

Compound 4, inhibition constant: 4470 nM
Estimate against measurement, compound 4: 5.0-fold (0.70 log units) below; the measured number lies above the stated range.
By their numbers in this assay, from the lowest: compound 3; then compounds 2 and 1 (each within the scatter of the next); then compound 4.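

In this assay, within the data shown here, the group on the carbonyl carbon matters far more than the earlier steps suggested: the change gives an 18-fold higher number from compound 2 to compound 4 (1.25 log units; beyond the scatter) and so stands well apart from the exchange of substituent on the same aromatic ring, which gave a 1.1-fold lower number from compound 1 to compound 2 (0.03 log units; within the scatter) and no readable change. The change removes the aromatic ring and the nitro group together, so this single step cannot assign the weaker inhibition to either one. Nothing measured here accounts for the size of the step.

Open, from the compounds shown here alone, is whether the shift follows the loss of the aromatic ring or of the nitro group, which an unsubstituted phenyl or a saturated cyclohexyl on the carbonyl carbon would help to separate. Also open, going by these compounds, is whether the bromo substitution seen in compound 3 would have any effect with cyclohex-1-en-1-yl in place.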